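The source may hold more compounds than are shown below. What is called first, only, known or untested is meant among the compounds shown, and "the series" means these compounds.

Of the compounds shown here, three have been tested in an ADME assay on HepG2 2.2.15 cells (Homo sapiens) for cytotoxicity; on this read-out lower numbers stand for higher toxicity in this test and higher numbers for lower toxicity in this test. Among the measured compounds shown here, compound 1 `Cn1c(=O)c(CCO)c(-c2ccccc2Cl)c2cc(Cl)ccc21` gives 34000 nM, and compound 2 `C=CCn1c(=O)c(CCO)c(-c2ccccc2Cl)c2cc(Cl)ccc21` gives 23000 nM; the step of a 1.5-fold lower number from compound 1 to compound 2 (0.17 log units; within the scatter) is the only one-change comparison among the measured compounds. Compound 3 `CC(=O)NCC(=O)OCCc1c(-c2ccccc2Cl)c2cc(Cl)ccc2[nH]c1=O` gives 110000 nM, the highest of the three numbers, lying beyond the scatter from compound 1 and from compound 2. Compound 4 `COc1ccc(/C=C/C(=O)OCCc2c(-c3ccccc3Cl)c3cc(Cl)ccc3[nH]c2=O)cc1` differs from compound 3 by 2-(4-methoxyphenyl)ethenyl in place of acetamidomethyl on a carbonyl carbon. For the measured compounds named here, no measured step involves this part of the molecule, so the single measured step offers no direct guide; only the spread among compounds 1, 2 and 3 is informative. Compound 4 is therefore expected to give roughly 50000 nM, within 15000 nM to 150000 nM, which would mean an expected step of a 2.2-fold lower number from compound 3 to compound 4 (0.34 log units; beyond the scatter).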

Compound 4, half-maximal cytotoxic concentration: > 1200000 nM
Compound 4: no number, only a limit; the forecaster's own chance of this, stated with the estimate: 10%; middle value at least 24-fold (1.38 log units) from the limit.
By their numbers in this assay, from the lowest: compounds 2 and 1 (each within the scatter of the next); then compound 3. At a limit, above all of these: compound 4.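

In this assay, the group on this carbonyl carbon can move the read-out strongly: 2-(4-methoxyphenyl)ethenyl in place of acetamidomethyl gives an at least 10-fold higher number from compound 3 to compound 4 (1.03 log units; beyond the scatter), in the direction of lower toxicity in this test. Among the compounds shown here, this is the first step seen at this place, and unlike the only earlier step, it lies beyond the scatter. The result for compound 4 is a limit, not a number: the limit of > 1200000 nM in this assay, at which 1 of the 4 values shown sits.

As far as these compounds go, the swap replaces the whole group at once, so it remains open which part of 2-(4-methoxyphenyl)ethenyl matters. From the compounds shown here alone, how a plain phenyl, a methyl or a carboxylic acid would read on this carbonyl carbon also remains open.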